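A few compounds are considered here, and "the series" means these few. Any claim that something is new, unique, unknown or untested is made for them only; others in the source may bear on it.

Compound 1 `CC(C)c1ccccc1-c1cc2cc(CCC(=O)O)ccc2[nH]1` carries an isopropyl group on the aryl ring that hangs from the shared core. In a functional assay on CHO cells for agonist activity at Free fatty acid receptor 1 (Homo sapiens), read by a luciferase reporter, with a stated time of 24 h (on this read-out higher numbers stand for an effect only at larger amounts of compound and lower numbers for an effect already at smaller amounts), compound 1 is reported only as a limit, > 25 nM. Compound 3 `COc1cccc(-c2cc3cc(CCC(=O)O)ccc3[nH]2)c1`, which carries a methoxy group instead, is likewise reported in this assay only as a limit, > 25 nM. Compound 2 `O=C(O)CCc1ccc2[nH]c(-c3ccccc3F)cc2c1` carries fluoro where compound 1 carries isopropyl, and in this assay compound 2 gives 1210 nM. The step that the limit leaves unreadable from compound 1 to compound 2 cannot be sized because the limit of > 25 nM in this assay, at which 2 of the 3 values shown sit, hides where compound 1 truly sits.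

Compound 4 `O=C(O)CCc1ccc2[nH]c(-c3ccccc3Cl)cc2c1` differs from compound 1 by chloro in place of isopropyl on an aromatic carbon. Going by the values given here, no measured step between two numbers bears on this change; the only neighbouring step, from isopropyl to fluoro, is unreadable, so the expectation rests on compound 2 alone. As compound 2 with fluoro at the same place gives 1210 nM, compound 4 with chloro there is expected to land in the same region. The estimate for compound 4 in this assay is 900 nM, with a range from 250 nM to 4000 nM. The expected step that the limit leaves unreadable from compound 1 to compound 4 cannot be checked against the limit of compound 1.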

Compound 4, half-maximal effective concentration: 54.6 nM
Estimate against measurement, compound 4: 16-fold (1.22 log units) above; the measured number lies below the stated range.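

In this assay, going by these compounds alone, the group on this aromatic carbon, ortho to a large group, now has a readable effect for the first time, since compound 2 and compound 4 are the first pair here with two real numbers. Chloro in place of fluoro gives a 22-fold lower number from compound 2 to compound 4 (1.35 log units; beyond the scatter), so the result with fluoro at this place does not carry over to chloro, and exchanging one single atom for another is enough to shift the effect to much smaller amounts of compound. The steps from compound 1 to compound 2 and to compound 4 still cannot be read, because the isopropyl compound is known only through a limit: the limit of > 25 nM in this assay, at which 2 of the 4 values shown sit.

As far as these compounds go, whether bromo or methyl at this place would give a number nearer to that of compound 4 or compound 2 remains open. The compounds shown also leave open why chloro and fluoro differ so widely, and where isopropyl truly stands against chloro.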